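This account rests on a few compounds, and the source may have more. Where it says the series, first, only, none or still open, it means among the compounds named here.

Working notes on a series of four compounds.

Compound 1 `N/C(=N\NC(=S)N1CCCCCC1)c1ccccn1` is the smallest member. In a functional assay on HeLa cells (Homo sapiens) for cytotoxicity, read by MTT assay, with a stated time of 72 h, tested at 1 uM (a lower number here means less inhibition of growth, a higher number more inhibition of growth at the concentration tested), compound 1 gives 21.3%. Compound 3 `Cc1cccc(/C(N)=N/NC(=S)N2CCCCCC2)n1` adds a methyl to the aromatic ring of compound 1; in this assay compound 3 gives 49.5%. Within the data shown here, the one measured change of its kind is a number 28.2 percentage points lower from compound 3 to compound 1 (beyond the scatter), described as hydrogen in place of methyl on an aromatic carbon. Compound 2 `Cc1ccnc(/C(N)=N/NC(=S)N2CCN(c3ccccn3)CC2)c1` is built on a different core; in this assay compound 2 gives 40.4%, a number within the scatter of the value of compound 3 and beyond the scatter above the value of compound 1. The difference between the core of compound 2 and the core of compound 3 is not broken down here.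

Compound 4 `N/C(=N\NC(=S)N1CCN(c2ccccn2)CC1)c1ccccn1` has not yet been measured in this assay. It differs from compound 2 by hydrogen in place of methyl on an aromatic carbon. This is the same kind of change as from compound 3 to compound 1, not the same: in the measured pair the methyl sits next to the ring nitrogen, in the new pair it sits opposite the ring nitrogen, in both cases meta to a large group. Because a number 28.2 percentage points lower from compound 3 to compound 1 (beyond the scatter) ran downward by a modest amount, a downward step is expected here as well, though the different place and the different core leave its size open. The estimated step is a number 22.4 percentage points lower from compound 2 to compound 4 (beyond the scatter). Compound 4 is expected to give 18%, with a range from 5% to 35%.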

Compound 4, percent growth inhibition at one concentration: 16.7%
Estimate against measurement, compound 4: 1.3 percentage points above, within the range that was stated.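

Replacing methyl with hydrogen on the aromatic ring of compound 2 gives, in this assay, a number 23.7 percentage points lower from compound 2 to compound 4 (beyond the scatter), and the size of this step does not differ from that of the earlier step on the other core: the same change on two cores in this assay, a number 28.2 percentage points lower (beyond the scatter) from compound 3 to compound 1 and a number 23.7 percentage points lower (beyond the scatter) from compound 2 to compound 4, 4.5 percentage points apart, within the scatter of two such steps Within these two pairs, then, the methyl-bearing compound gives the higher growth inhibition in both cases, and the change carries from one core to the other in both direction and size. Among these compounds, this does not establish a general rule, as it rests on only two pairs at a single tested concentration, the methyl does not occupy the same place on the ring in both pairs, and the data do not explain why removing the methyl lowers the read-out.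

As far as these compounds go, it remains open how an ethyl group, a methoxy group, a chlorine atom or an amine at the place opposite the ring nitrogen would compare with methyl and hydrogen. Also open, from the compounds shown here alone, is whether the step would hold on a third core, or in any read-out other than this assay.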